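Adding a chloro to the compound 3 series

The source may hold more compounds than are shown below. What is called first, only, known or untested is meant among the compounds shown, and "the series" means these compounds.

Measured so far in an ADME assay on CCRF-CEM cells (Homo sapiens) for antiproliferative activity, with a stated time of 48 h; on this read-out higher numbers stand for weaker inhibition and lower numbers for stronger inhibition:
Compound 1 `C=C(Br)C(=O)Nc1ccc(/C=C/C(=O)c2ccc(Cl)c(Cl)c2)cc1`: 1700 nM
Compound 2 `Nc1ccc(/C=C/C(=O)c2ccccc2)cc1`: 34000 nM
Compound 3 `Nc1ccc(/C=C/C(=O)c2ccc(Cl)cc2)cc1`: 21000 nM

Compound 3, at 21000 nM, cannot be told apart from compound 2, at 34000 nM, and gives a clearly higher number than compound 1, at 1700 nM. Compound 4 `Nc1ccc(/C=C/C(=O)c2ccc(Cl)c(Cl)c2)cc1` differs from compound 3 by one change, chloro in place of hydrogen on an aromatic carbon, ortho to a chloro group. Among the measured compounds shown here, one measured step bears on it, the same exchange made elsewhere: a 1.6-fold lower number from compound 2 to compound 3 (0.21 log units; within the scatter). A similarly small step is therefore expected in this assay, toward a lower number if any, and none beyond the scatter: the expected step is a 1.5-fold lower number from compound 3 to compound 4 (0.18 log units; within the scatter). For compound 4 the estimated value is 14000 nM, with an expected range of 6000 nM to 30000 nM.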

Compound 4, half-maximal inhibitory concentration: 15000 nM
The estimate for compound 4 lay 1.1-fold (0.03 log units) below the measured number; the range from low to high includes it.
By their numbers in this assay, from the lowest: compound 1; then compounds 4, 3 and 2 (each within the scatter of the next, the first and the last beyond it).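

In this assay, a second chloro on the ring, ortho to a chloro group, gives a 1.4-fold lower number from compound 3 to compound 4 (0.15 log units; within the scatter), so this position tolerates the exchange without a step beyond the scatter. On the same compound, hydrogen in place of (1-bromoethenyl)carbonyl on the nitrogen gives an 8.8-fold higher number from compound 1 to compound 4 (0.95 log units; beyond the scatter), a step beyond the scatter. No measurement at hand accounts for either step. From the compounds shown here alone, whether a methoxy or a nitrile at this position would also stay within the scatter remains open. So does whether the (1-bromoethenyl)carbonyl would give a similar step on compound 3 or compound 2.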